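The source may report more compounds than this note shows. Statements on the series, on what has been measured and on what is new or still open speak of the compounds shown alone.

Measured so far in an assay for binding affinity to Alpha-1A adrenergic receptor (Homo sapiens), read by radioligand binding; on this read-out lower numbers stand for stronger inhibition and higher numbers for weaker inhibition:
Compound 1 `CS(=O)(=O)c1ccc(F)cc1NCC1=NCCN1`: 813 nM
Compound 2 `CSc1ccc(F)cc1NCC1=NCCN1`: 33.1 nM
Compound 3 `CSc1c(F)cccc1NCC1=NCCN1`: 148 nM

Compound 2 gives the lowest number of the three; compound 3 sits higher and compound 1 higher still, both gaps beyond the scatter. Among the measured compounds shown here, the one single-point step measured, a 25-fold lower number from compound 1 to compound 2 (1.39 log units; beyond the scatter), concerns the sulfur group and is large.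

Compound 4 `CSc1ccc(Cl)cc1NCC1=NCCN1` differs from compound 2 by chloro in place of fluoro on an aromatic carbon. For the measured compounds named here, no measured step touches this halogen: the step from compound 1 to compound 2 changes the sulfur group, and compounds 2 and 3 differ in where the fluoro sits, not in which halogen is present. A step for compound 4 is therefore expected to stay close to compound 2, with a 1.1-fold lower number from compound 2 to compound 4 (0.04 log units; within the scatter) as the working guess. For compound 4 the expected value in this assay is 30 nM, with a range from 10 nM to 90 nM.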

Compound 4, inhibition constant: 18.6 nM
Estimate against measurement, compound 4: 1.6-fold (0.21 log units) above; low and high end bracket the measured number.
By their numbers in this assay, from the lowest: compounds 4 and 2 (each within the scatter of the next); then compound 3; then compound 1.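

Chloro in place of fluoro on the aromatic carbon para to a methylsulfanyl group gives a 1.8-fold lower number from compound 2 to compound 4 (0.25 log units; within the scatter) in this assay, so this position accepts either halogen with no shift beyond the scatter. Among the compounds shown here, the earlier compounds showed only that the sulfur group and the placement of fluoro matter; the identity of this halogen does not show the same sensitivity here. No supporting data explain this result.

Still open, on these data alone, is whether a methoxy group, an amine or a nitrile at this carbon would stay close to these two halogens. Also open, as far as these compounds go, is whether chloro behaves alike with a methylsulfonyl group on the core.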